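From Methylamino to Carboxy on a Shared Core

The source may hold more compounds than are shown below. What is called first, only, known or untested is meant among the compounds shown, and "the series" means these compounds.

Values measured in a toxicity assay on CCRF-CEM cells (Homo sapiens) for cytotoxicity; a lower number here means that less compound is tolerated, a higher number that more compound is tolerated:
- compound 1 `COC(=O)c1cccc2c1nc(-c1c(F)cccc1F)n2Cc1c(F)cccc1F`: 57.7 uM
- compound 2 `Fc1cccc(F)c1Cn1c(-c2c(F)cccc2F)nc2c(Br)cccc21`: 24.5 uM
- compound 3 `CNc1cccc2c1nc(-c1c(F)cccc1F)n2Cc1c(F)cccc1F`: 27.2 uM

These three compounds differ at one aromatic carbon. The top number belongs to compound 1, which carries methoxycarbonyl there. The data show a 2.4-fold lower number from compound 1 to compound 2 (0.37 log units; beyond the scatter), and also a 2.1-fold lower number from compound 1 to compound 3 (0.33 log units; beyond the scatter). Both steps are modest. The remaining pair shows a 1.1-fold higher number from compound 2 to compound 3 (0.05 log units; within the scatter), so those two sit level. Compound 3 therefore shares the lower level with compound 2.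

The next compound is compound 4 `O=C(O)c1cccc2c1nc(-c1c(F)cccc1F)n2Cc1c(F)cccc1F`. The change is carboxy in place of methylamino on an aromatic carbon. Among the measured compounds shown here, no measured compound carries carboxy, so there is no direct precedent. The nearest guide is compound 1, whose methoxycarbonyl group is the closest in structure to carboxy among the three groups tested. Its value of 57.7 uM and the modest step of a 2.1-fold lower number from compound 1 to compound 3 (0.33 log units; beyond the scatter) suggest that leaving methylamino for this kind of group should raise the number by a modest amount in this assay. The expected change is a 2.0-fold higher number from compound 3 to compound 4 (0.31 log units; beyond the scatter). For compound 4 the estimated value is 55 uM, with an expected range from 22 uM to 130 uM.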

Compound 4, half-maximal toxic concentration: 23.5 uM
For compound 4 the middle estimate is 2.3-fold (0.37 log units) above the measured one, and the stated range covers the measured number.
By their numbers in this assay, from the lowest: compounds 4, 2 and 3 (each within the scatter of the next); then compound 1.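

In this assay, carboxy in place of methylamino on this aromatic carbon brings no real shift (a step of a 1.2-fold lower number from compound 3 to compound 4 (0.06 log units; within the scatter)), and carboxy in place of bromo brings none either (a step of a 1.0-fold lower number from compound 2 to compound 4 (0.02 log units; within the scatter)). The most informative comparison is the closest pair, since hydrogen in place of the methyl of methoxycarbonyl is a small edit and still gives a modest step beyond the scatter (a step of a 2.5-fold lower number from compound 1 to compound 4 (0.39 log units; beyond the scatter)). Among the four groups tested here, bromo, methylamino and carboxy therefore share one level while methoxycarbonyl alone stands higher, so close structural resemblance to compound 1 was not enough for compound 4 to share its number.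

Nothing available here explains why methoxycarbonyl stands apart from the other three groups.
Also open, going by these compounds, is whether a longer ester such as ethoxycarbonyl, or a carboxamide, on this same carbon of the shared core would sit with compound 1 or with the lower three, which would show whether the higher number belongs to methoxycarbonyl alone.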